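Carbonyl substituent step from compound 2 to compound 4

The compounds below may be only part of what the source reports. "The series", "measured", "known", "first", "only" and "open" are said of these compounds alone.

Measured in an assay on cells for antagonist activity at Neuronal acetylcholine receptor; alpha3/beta4 (Homo sapiens), read by two-electrode voltage clamp, with a stated time of 1 min; on this read-out higher numbers stand for weaker inhibition and lower numbers for stronger inhibition:
compound 1 `NCCCNCCCCNCCCNC(=O)[C@H](CC1CCCCC1)NC(=O)C1CCCC1` gives 0.65 nM
compound 2 `NCCCNCCCCNCCCNC(=O)[C@H](CC1CCCCC1)NC(=O)CC1CC2CCC1C2` gives 0.95 nM
compound 3 `NCCCNCCCCNCCCNC(=O)[C@H](CC1CCCCC1)NC(=O)c1ccccc1` gives 0.37 nM

Compound 2 holds the highest of the three numbers in this assay; the step of a 1.5-fold higher number from compound 1 to compound 2 (0.16 log units; within the scatter) is within the scatter, whereas a 2.6-fold lower number from compound 2 to compound 3 (0.41 log units; beyond the scatter) lies beyond it. Compound 4 `NCCCNCCCCNCCCNC(=O)[C@H](CC1CCCCC1)NC(=O)c1ccc(-c2ccccc2)cc1` carries a group of 12 heavy atoms (12 carbon; 2 six-membered aromatic rings of carbon only) in place of a group of 8 heavy atoms (8 carbon; 2 five-membered non-aromatic rings of carbon only), on a carbonyl carbon. Among the compounds with values here, the steps that bear on this change are a 2.6-fold lower number from compound 2 to compound 3 (0.41 log units; beyond the scatter) and, for a larger group on the same carbon, a 1.5-fold higher number from compound 1 to compound 2 (0.16 log units; within the scatter); the first links a six-membered aromatic ring on that carbon with a lower number, the second shows that added size alone changed little. A modest downward step is therefore expected, a 2.1-fold lower number from compound 2 to compound 4 (0.32 log units; beyond the scatter). Compound 4 is estimated at 0.45 nM, within 0.15 nM to 1.4 nM.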

Compound 4, half-maximal inhibitory concentration: 2.83 nM
For compound 4 the middle estimate is 6.3-fold (0.80 log units) below the measured one, outside the stated range (above it).
By their numbers in this assay, from the lowest: compounds 3, 1 and 2 (each within the scatter of the next, the first and the last beyond it); then compound 4.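

In this assay 4-phenylphenyl on the carbonyl carbon gives a higher number than each of the other three groups: a 7.6-fold higher number from compound 3 to compound 4 (0.88 log units; beyond the scatter) against phenyl, a 4.4-fold higher number from compound 1 to compound 4 (0.64 log units; beyond the scatter) against cyclopentyl and a 3.0-fold higher number from compound 2 to compound 4 (0.47 log units; beyond the scatter) against the group of compound 2. An aromatic ring on this carbon therefore does not by itself go with a low number, and added size here is not without effect. Nothing available explains this rise.

From the compounds shown here alone, it remains open whether any group on the phenyl of compound 3 raises the number or only a second ring does; 4-methylphenyl or 4-aminophenyl would address this.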